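The source may report more compounds than this note shows. Statements on the series, on what has been measured and on what is new or still open speak of the compounds shown alone.

In a functional assay on HeLa cells (Homo sapiens) for inhibition, read by sulforhodamine B assay (on this read-out higher numbers stand for weaker inhibition and lower numbers for stronger inhibition), two compounds sharing the same core have been measured. Compound 1 `O=C1C(Nc2ccc(Br)cc2)=CC(=O)c2c1nc1n2[C@H]2OC[C@@H](O)[C@H]2OC1`, which carries (4-bromophenyl)amino, gives 5220 nM. Compound 2 `O=C1C(N2CCCC2)=CC(=O)c2c1nc1n2[C@H]2OC[C@@H](O)[C@H]2OC1`, which carries pyrrolidin-1-yl in that place, gives > 16000 nM, and this is a limit of the assay and not a number.

Compound 3 `COc1ccc(NC2=CC(=O)c3c(nc4n3[C@H]3OC[C@@H](O)[C@H]3OC4)C2=O)cc1`, not yet measured, has (4-methoxyphenyl)amino in place of pyrrolidin-1-yl on a double-bonded ring carbon. Among the measured compounds shown here, the one measured step that bears on this change is an at least 3.0-fold higher number from compound 1 to compound 2 (0.48 log units; beyond the scatter), in which (4-bromophenyl)amino gave way to pyrrolidin-1-yl. Compound 3 brings back a phenylamino group with a different substituent, so a move of similar size in the opposite direction, toward a lower number and stronger inhibition, is expected. The expected step is an at least 2.6-fold lower number from compound 2 to compound 3 (0.42 log units; beyond the scatter). The estimated value for compound 3 is 6000 nM, within an expected range of 2200 nM to 15000 nM.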

Compound 3, half-maximal inhibitory concentration: > 8000 nM
Compound 3 ended at the assay's limit (the forecaster's own chance of this, stated with the estimate: 15%); at least 1.3-fold (0.12 log units) between middle value and limit.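

In this assay compound 3 gives > 8000 nM, which is a limit of the assay and not a number. Methoxy in place of bromo on an aromatic carbon gives an at least 1.5-fold higher number from compound 1 to compound 3 (0.18 log units; that floor lies within the scatter), so the change from bromo to methoxy is not shown to go beyond the scatter, although the true gap could be larger. The step between compound 2 and compound 3 cannot be read, as both end at limits, and a (4-methoxyphenyl)amino group in this place therefore gives no number, unlike the (4-bromophenyl)amino group of compound 1.

On these data alone, the size of the true gap between bromo and methoxy remains open. So does what a plain phenylamino group, or one carrying chloro, a nitrile or a carboxylic acid on the aromatic ring, would give in this place.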